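This account rests on a few compounds, and the source may have more. Where it says the series, first, only, none or still open, it means among the compounds named here.

Measured so far in a physicochemical assay for lipophilicity, read by HPLC, at pH 7.4; on this read-out lower numbers stand for lower lipophilicity and higher numbers for higher lipophilicity:
compound 1 `O=C(O)c1ccc([C@H]2CC[C@]3(CC2)OOC2(O3)C3CC4CC(C3)CC2C4)cc1` gives 3
compound 2 `CCOC(=O)COc1ccc([C@H]2CC[C@]3(CC2)OOC2(O3)C3CC4CC(C3)CC2C4)cc1` gives > 5.3

Compound 2 stands only at the upper limit of this assay; the reading > 5.3 is a limit of the assay and not a number (the limit of > 5.3 in this assay, at which 1 of the 2 values shown sits). Compound 3 `O=C(O)CCCOc1ccc([C@H]2CC[C@]3(CC2)OOC2(O3)C3CC4CC(C3)CC2C4)cc1` is not yet measured. It differs from compound 2 as follows: 2-carboxyethyl in place of ethoxycarbonyl on a saturated chain carbon bound to an oxygen on an aromatic ring. Going by the values given here, the one measured step, a number at least 2.30 log units higher from compound 1 to compound 2 (beyond the scatter), exchanged an acid for an ester and was large, in the upward direction. The step from compound 2 to compound 3 runs the other way, from an ester back to an acid, so a large downward step is expected in this assay, estimated as a number at least 1.70 log units lower from compound 2 to compound 3 (beyond the scatter). Compound 1 carries a carboxy group and gives 3. Compound 3, with its acid set on a longer chain, is estimated at 3.6, expected to fall between 2.8 and 4.4.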

Compound 3, distribution coefficient: 3.6
Beside the measured number, compound 3's estimate shows no gap at the digits printed; low and high end bracket the measured number.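

In this assay compound 2 gives > 5.3, a limit and not a number: the limit of > 5.3 in this assay, at which 1 of the 3 values shown sits.

With the same chain kept, 2-carboxyethyl in place of ethoxycarbonyl on a saturated chain carbon bound to an oxygen on an aromatic ring gives a number at least 1.70 log units lower from compound 2 to compound 3 (beyond the scatter), so the change from ester to carboxylic acid is now seen at one place alone, with the true size of the step still bounded. With the carboxylic acid kept, the reading is a number 0.60 log units higher from compound 1 to compound 3 (beyond the scatter), a modest step set against the two large ones.

The three compounds leave open how the reading runs with a shorter acid chain such as carboxymethoxy, or with a longer one. They also leave open what an amide or an amine at the end of the chain would give in this assay.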